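Removing a Cyclobutylmethyl Group from a Sulfonamide Nitrogen

A few compounds are considered here, and "the series" means these few. Any claim that something is new, unique, unknown or untested is made for them only; others in the source may bear on it.

Of the compounds shown here, two have been measured in a physicochemical assay for lipophilicity, at pH 7.4; on this read-out higher numbers stand for higher lipophilicity and lower numbers for lower lipophilicity. Compound 1 `CCc1ccc(N(CC(C)C)S(=O)(=O)c2ccc3c(c2)C(O)CC(C2CCN(S(C)(=O)=O)CC2)O3)cc1` gives 3.22 in this assay. Compound 2 `CCc1ccc(N(CC2CCC2)S(=O)(=O)c2ccc3c(c2)C(O)CC(C2CCOCC2)O3)cc1` gives 4.01 in this assay, the higher of the two numbers, and the gap to compound 1 lies beyond the scatter. Compound 3 `CCc1ccc(NS(=O)(=O)c2ccc3c(c2)C(O)CC(C2CCOCC2)O3)cc1` has not yet been measured. It differs from compound 2 in one place: hydrogen in place of cyclobutylmethyl on a sulfonamide nitrogen. For the measured compounds named here, no step between measured compounds resembles this change. Compound 3 is expected to fall clearly in this assay, by a step of a number 1.71 log units lower from compound 2 to compound 3 (beyond the scatter). Compound 3 is therefore estimated at 2.3, between 1.7 and 2.9.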

Compound 3, distribution coefficient: 2.59
For compound 3 the middle estimate is 0.29 log units below the measured one, and the stated range covers the measured number.
By their numbers in this assay, from the lowest: compound 3; then compound 1; then compound 2.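

In this assay the read-out moves by a number 1.42 log units lower from compound 2 to compound 3 (beyond the scatter) when hydrogen takes the place of cyclobutylmethyl on a sulfonamide nitrogen, and this is the only step shown at this position. One swap, with the rest of the molecule unchanged, is enough for a large shift. Nothing among the data shown gives a reason for this step.

A single pair cannot show how the number depends on the group at this nitrogen. Methyl, a longer chain or a chain ending in an amine could show whether smaller or different groups give smaller steps.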